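The source may report more compounds than this note shows. Statements on the series, on what has been measured and on what is new or still open speak of the compounds shown alone.

Measured compounds:
Compound 1 `CCC(CC)(c1ccc(OCC(CO)CO)c(C)c1)c1ccc(OCC(C)(C)O)c(C)c1` gives 76.5 nM in an assay on HOS cells for agonist activity at vitamin D3 receptor (Homo sapiens), read by a luciferase reporter; on this read-out lower numbers stand for an effect already at smaller amounts and higher numbers for an effect only at larger amounts of compound.
Compound 2 `CCC(O)(CC)COc1ccc(C(CC)(CC)c2ccc(OCC(CO)CO)c(C)c2)cc1C` gives 9.26 nM in this assay.
Compound 3 `CCC(CC)(c1ccc(OCCC(C)(C)O)c(C)c1)c1ccc(OC[C@@H](O)CO)c(C)c1` gives 41.7 nM in this assay.

Compound 3 stands second highest of the three numbers. Its nearest neighbour is compound 1, a gap within the usual scatter; compound 2 lies further off, beyond it. Among the measured compounds shown here, the only single-point step measured is an 8.3-fold lower number from compound 1 to compound 2 (0.92 log units; beyond the scatter), and it concerns the tertiary alcohol side of the shared core, not the diol side.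

Compound 4 `CCC(CC)(c1ccc(OCCC(C)(C)O)c(C)c1)c1ccc(OCC(CO)CO)c(C)c1` differs from compound 3 in one place: 2-hydroxy-1-(hydroxymethyl)ethyl in place of 1,2-dihydroxyethyl on a saturated chain carbon bound to an oxygen on an aromatic ring. For the measured compounds named here, no measured pair isolates this change. Compounds 1 and 2 both already carry the group that enters and differ from each other elsewhere, so the step between them gives no reading on the diol side. Compound 1 and compound 4 share the group that enters and differ elsewhere; the values of compound 1 and compound 3 sit within the scatter of each other, which gives no sign that the diol side moves the number much. The step from compound 3 to compound 4 is therefore expected to be small, estimated as a 1.1-fold higher number from compound 3 to compound 4 (0.03 log units; within the scatter). Compound 4 is expected near 45 nM, with a range from 15 nM to 130 nM.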

Compound 4, half-maximal effective concentration: 76.9 nM
Compound 4: middle estimate off by 1.7-fold (0.23 log units), on the low side; the range from low to high includes it.
By their numbers in this assay, from the lowest: compound 2; then compounds 3, 1 and 4 (each within the scatter of the next).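

In this assay the exchange of 1,2-dihydroxyethyl for 2-hydroxy-1-(hydroxymethyl)ethyl on a saturated chain carbon bound to an oxygen on an aromatic ring now has a direct reading in a 1.8-fold higher number from compound 3 to compound 4 (0.27 log units; within the scatter) and so stays within the scatter, with the tertiary alcohol side held constant. On that tertiary alcohol side, 2-hydroxy-2-methylpropyl in place of 1-hydroxy-1-methylethyl gives a 1.0-fold higher number from compound 1 to compound 4 (0.00 log units; within the scatter) and also stays within the scatter, while 2-hydroxy-2-methylpropyl in place of 1-ethyl-1-hydroxypropyl gives an 8.3-fold higher number from compound 2 to compound 4 (0.92 log units; beyond the scatter) and lies beyond it, so that among these four compounds the steps beyond the scatter all involve compound 2 and its 1-ethyl-1-hydroxypropyl group. Nothing at hand accounts for these steps.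

Open, going by these compounds, is whether the lower number of compound 2 holds when 1-ethyl-1-hydroxypropyl is paired with 1,2-dihydroxyethyl, or when the ethyl groups give way to longer chains. Also open, on these data alone, is how this read-out responds to the opposite stereocentre in 1,2-dihydroxyethyl, or to a carboxylic acid or an amine in place of the diol.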